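The compounds below may be only part of what the source reports. "The series", "measured", "known", "first", "only" and "open" are said of these compounds alone.

Two measured compounds share a fused core that carries a chloro group on one ring and a benzyl arm bearing a chloromethyl group. Compound 1 `ClCc1ccc(Cn2cnc3c(Cl)ncnc32)cc1` has a hydrogen on the aromatic carbon between the two ring nitrogen atoms, and in a functional assay on ACHN cells (Homo sapiens) for cytotoxicity, read by sulforhodamine B assay, with a stated time of 48 h (a lower number here means a stronger inhibitor of growth, a higher number a weaker inhibitor of growth), compound 1 gives 1280 nM. Compound 2 `Nc1nc(Cl)c2ncn(Cc3ccc(CCl)cc3)c2n1` carries an amino group at that same carbon, and in this assay compound 2 gives 25100 nM. Within the data shown here, of the two numbers, compound 2 has the higher one, so it is the weaker inhibitor of growth; the single measured step, a 20-fold higher number from compound 1 to compound 2 (1.29 log units; beyond the scatter), shows how much adding the amino group cost.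

Compound 3 `ClCc1ccc(Cn2cnc3c(Cl)nc(Cl)nc32)cc1` is not yet measured. It differs from compound 2 as follows: chloro in place of amino on an aromatic carbon. Among the measured compounds shown here, the one step that bears on this is the hydrogen-to-amino change from compound 1 to compound 2, which was large and toward weaker inhibition. Removing the amino group is therefore expected to move the number back down, though chloro is not hydrogen and the size of the return is uncertain. The expected step is an 8.4-fold lower number from compound 2 to compound 3 (0.92 log units; beyond the scatter). For compound 3 the estimated value in this assay is 3000 nM, within a range from 800 nM to 12000 nM.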

Compound 3, concentration for total growth inhibition: 5250 nM
Compound 3: the middle estimate sits 1.8-fold (0.24 log units) below what was measured; low and high end bracket the measured number.
By their numbers in this assay, from the lowest: compound 1; then compound 3; then compound 2.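

In this assay, amino is not the only replacement for hydrogen at this carbon between two ring nitrogen atoms that raises the number, since chloro gives a 4.1-fold higher number from compound 1 to compound 3 (0.61 log units; beyond the scatter) as well. Putting chloro in place of amino recovers only part of the loss, with a 4.8-fold lower number from compound 2 to compound 3 (0.68 log units; beyond the scatter) as the measured return, so compound 3 falls between the other two. At this one carbon the three groups now form an order, with hydrogen giving the lowest number, chloro the middle one and amino the highest, and each gap lies beyond the scatter, but no measurement shown here explains that order.

On these data alone, it remains open whether any other group at this carbon, such as fluoro, methyl or methoxy, would give a lower number than the hydrogen of compound 1 or would instead raise it as chloro and amino do. As far as these compounds go, it is also open whether the same order of hydrogen, chloro and amino would hold if a plain methyl group replaced the chloromethyl group on the benzyl arm.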